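The compounds below may be only part of what the source reports. "The series", "measured", "known", "first", "only" and "open" are said of these compounds alone.

Measured so far in a functional assay on the whole organism with Rattus norvegicus as the target; on this read-out higher numbers stand for an effect only at larger amounts of compound and lower numbers for an effect already at smaller amounts

Compound 1 `COc1cc(N)c(Cl)cc1C(=O)NCCN(C)C(C)c1ccccc1` gives 1 mg/kg
Compound 2 `COc1cc(N(C)C)c(Cl)cc1C(=O)NC1CCN(Cc2ccccc2)C1` gives 0.12 mg/kg
Compound 3 `COc1cc(N(C)C)c(Cl)cc1C(=O)NC1CCN(C2CCCCC2)C1` gives 1 mg/kg

Compound 2 holds the lowest of these three numbers, and compound 1 and compound 3 share the same higher value. Compound 4 `COc1cc(NCc2ccccc2)c(Cl)cc1C(=O)NC1CCN(Cc2ccccc2)C1` differs from compound 2 in a single group, with benzylamino in place of dimethylamino on an aromatic carbon at that site, ortho to a chloro group. Among the measured compounds shown here, only one measured step is available, an 8.3-fold higher number from compound 2 to compound 3 (0.92 log units; beyond the scatter) in size, and it puts cyclohexyl in place of benzyl on an amine nitrogen in a ring. That is a different place in the molecule, so it serves only as a yardstick for how far one replacement can move this assay in this set. For the measured compounds named here, no measured pair isolates a change on the aromatic carbon itself, and compound 1 differs from compound 2 in more than that group. A modest step toward a higher number is expected, with little direct support. The expected step is a 3.3-fold higher number from compound 2 to compound 4 (0.52 log units; beyond the scatter) on this reasoning. Compound 4 is estimated at 0.4 mg/kg with a range of 0.08 mg/kg to 2 mg/kg around it.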

Compound 4, dose for half-maximal effect: > 30 mg/kg
Compound 4 gave a limit, no number; the forecaster's own chance of this, stated with the estimate: 5%; middle value at least 75-fold (1.87 log units) from the limit.
By their numbers in this assay, from the lowest: compound 2; then compounds 1 and 3 (each within the scatter of the next). At a limit, above all of these: compound 4.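

In this assay, among the compounds shown here, the aromatic carbon that carries dimethylamino in compound 2 turns out to be highly sensitive to change: benzylamino there gives an at least 250-fold higher number from compound 2 to compound 4 (2.39 log units; beyond the scatter), well past the only earlier single-place step, an 8.3-fold higher number from compound 2 to compound 3 (0.92 log units; beyond the scatter), made on the amine nitrogen in a ring. Compound 2 and compound 4 share the benzyl group on that ring nitrogen, so the whole difference between them lies at this aromatic carbon. Compound 4 stands at a limit of the assay, not at a number: the limit of > 30 mg/kg in this assay, at which 1 of the 4 values shown sits.

The change brings in a six-membered aromatic ring and a hydrogen-bond donor together, and the compounds shown do not separate the two. Methylamino would carry the donor without the ring and N-benzyl-N-methylamino the ring without the donor, and either could tell them apart.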